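Methoxy to isopropoxy on a shared core: inhibition notes

A few compounds are considered here, and "the series" means these few. Any claim that something is new, unique, unknown or untested is made for them only; others in the source may bear on it.

Measured so far:
compound 1 `Cc1ccc(-c2oc3ccc(C(=O)O)cc3c(=O)c2O)cc1`: 6% in a functional assay on the whole organism (stomach) for inhibition, with Rattus norvegicus as the target, at a dose of 80 mg/kg; a higher number here means more inhibition at the dose given (going by the name of the read-out), a lower number less inhibition
compound 2 `COc1c(-c2ccc(C)cc2)oc2ccc(C(=O)O)cc2c1=O`: 4%
compound 3 `Cc1ccc(-c2oc3ccc(C(=O)O)cc3c(=O)c2OC(C)C)cc1`: not yet measured

Compound 2 holds the lowest of the two numbers recorded, and the nearest, compound 1, sits a number higher within the scatter, so the two cannot be ordered. Within the data shown here, the one recorded step, a number 2 percentage points lower from compound 1 to compound 2 (within the scatter), is likewise within the scatter: methyl in place of hydrogen on the oxygen on the aromatic ring moved nothing that can be read.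

Compound 3 differs from compound 2 by isopropyl in place of methyl on an oxygen on an aromatic ring. Among the measured compounds shown here, the only step that bears on this place is the one from compound 1 to compound 2, at the same oxygen, and it was within the scatter. Both measured compounds give low inhibition in this assay, and the recorded step at this oxygen gives no reason to expect the larger alkyl to move the number beyond the scatter; the step from compound 2 is therefore estimated as a number 1 percentage points higher from compound 2 to compound 3 (within the scatter). Compound 3 is expected to give 5%, with a range of -5% to 18%.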

Compound 3, a percentage reported as inhibition, in the whole organism at one dose (the size of the read-out at that dose, not a potency): 8%
Estimate against measurement, compound 3: 3 percentage points below; low and high end bracket the measured number.
By their numbers in this assay, from the lowest: compounds 2, 1 and 3 (each within the scatter of the next).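

In this assay this oxygen on an aromatic ring now carries isopropyl as well as hydrogen and methyl, which widens the comparison beyond the earlier pair. Isopropyl in place of methyl gives a number 4 percentage points higher from compound 2 to compound 3 (within the scatter) and isopropyl in place of hydrogen gives a number 2 percentage points higher from compound 1 to compound 3 (within the scatter), so none of the three groups on this oxygen can be told apart from the others in this assay, and enlarging the alkyl group from methyl to isopropyl yields no readable step. Nothing at hand accounts for this flat picture at the oxygen.

As far as these compounds go, whether a group of another kind on this oxygen, such as a longer chain ending in an amine or a carboxylic acid, would carry the number beyond the scatter remains open. Also open is whether an amide in place of the carboxylic acid on the shared core would give a readable step in this assay, since every compound shown keeps that acid.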